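Aromatic styryl sulfones: from a nitro group to an amino acid

A few compounds are considered here, and "the series" means these few. Any claim that something is new, unique, unknown or untested is made for them only; others in the source may bear on it.

Compound 1 `COc1cc(OC)c(/C=C/S(=O)(=O)Cc2ccc(OC)c([N+](=O)[O-])c2)c(OC)c1` is the starting point of this account. Going by the values given here, in a functional assay on DU-145 cells (Homo sapiens) for cytotoxicity, read by trypan blue exclusion, with a stated time of 96 h (on this read-out lower numbers stand for stronger inhibition and higher numbers for weaker inhibition), compound 1 gives 2500 nM, the lowest of the three numbers so far. Its two measured companions carry a halogen where compound 1 carries a methoxy group: compound 2 `COc1cc(OC)c(/C=C/S(=O)(=O)Cc2ccc(Br)c([N+](=O)[O-])c2)c(OC)c1` gives 25000 nM in this assay, and compound 3 `COc1cc(OC)c(/C=C/S(=O)(=O)Cc2ccc(F)c([N+](=O)[O-])c2)c(OC)c1` gives 25000 nM. The steps of a 10-fold higher number from compound 1 to compound 2 (1.00 log units; beyond the scatter) and a 10-fold higher number from compound 1 to compound 3 (1.00 log units; beyond the scatter) are each beyond the scatter, while no change at the digits printed from compound 2 to compound 3 (within the scatter).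

Compound 4 `COc1cc(OC)c(/C=C/S(=O)(=O)Cc2ccc(OC)c(N[C@@H](C)C(=O)O)c2)c(OC)c1` has not yet been measured. It differs from compound 1 in one place: (1-carboxyethyl)amino in place of nitro on an aromatic carbon. Among the compounds with values here, no measured step touches the nitro group; the two known steps concern the methoxy group alone, so they offer no direct guide to this exchange. Within the data shown here, the nitro group is part of the only pattern in which compound 1 stands lowest, and its removal is expected to cost rather than gain. For compound 4 the estimated step is therefore a 2.5-fold lower number from compound 1 to compound 4 (0.40 log units; beyond the scatter), giving an expected value of 1000 nM in this assay, with a range from 100 nM to 10000 nM.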

Compound 4, half-maximal inhibitory concentration: 25 nM
For compound 4 the middle estimate is 40-fold (1.60 log units) above the measured one, and the stated range ends above it.
By their numbers in this assay, from the lowest: compound 4; then compound 1; then compounds 2 and 3 (each within the scatter of the next).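

In this assay, going by these compounds alone, the first change at this position, on an aromatic carbon ortho to a methoxy group, gives a 100-fold lower number from compound 1 to compound 4 (2.00 log units; beyond the scatter), where the earlier steps had concerned only the methoxy group. The nitro group is thus not required for activity in this series, and the position accepts the larger (1-carboxyethyl)amino group with a large fall in the number. No measurement shown here accounts for the size of this step.

The compounds shown leave open whether a simple amine at this position, without the carboxylic acid, would give a similar number, and whether an ester or a longer chain would serve as well. They also leave open what the defined stereocentre contributes, and whether a halogen in place of the methoxy group would still raise the number in this new setting.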